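The source may report more compounds than this note shows. Statements on the series, on what has been measured and on what is new or still open speak of the compounds shown alone.

Measured compounds:
Compound 1 `CC1(C)[C@H]2CC[C@]1(C)N(Cc1cn(-c3ccc(C#N)cc3)nn1)C(=O)C2`: 15700 nM
Compound 2 `CC1(C)[C@H]2CC[C@]1(C)N(Cc1cn(-c3ccccc3C#N)nn1)C(=O)C2`: 46100 nM

In an ADME assay on L02 cells (Homo sapiens) for cytotoxicity, read by MTT assay, with a stated time of 24 h (a lower number here means that less compound is tolerated, a higher number that more compound is tolerated), compound 2 gives 46100 nM, the higher of the two numbers. Compound 3 `CC1(C)[C@H]2CC[C@]1(C)N(Cc1cn(-c3ccccc3F)nn1)C(=O)C2` carries fluoro in place of cyano on an aromatic carbon, ortho to a large group: fluoro in place of cyano on an aromatic carbon. Within the data shown here, the only measured step, a 2.9-fold higher number from compound 1 to compound 2 (0.47 log units; beyond the scatter), keeps the cyano group, so it bears on this change only loosely. Among the measured compounds shown here, no measured step exchanges cyano for fluoro. No step beyond the scatter is therefore expected, and the estimated step is a 1.3-fold lower number from compound 2 to compound 3 (0.12 log units; within the scatter). For compound 3 the expected value is 35000 nM, with an estimated range of 13000 nM to 90000 nM.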

Compound 3, half-maximal cytotoxic concentration: 13300 nM
Compound 3: middle estimate off by 2.6-fold (0.42 log units), on the high side; low and high end bracket the measured number.
By their numbers in this assay, from the lowest: compounds 3 and 1 (each within the scatter of the next); then compound 2.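

In this assay, exchanging cyano for fluoro on an aromatic carbon, ortho to a large group, is not a neutral change: the result is a 3.5-fold lower number from compound 2 to compound 3 (0.54 log units; beyond the scatter). The other new comparison, 2-fluorophenyl in place of 4-cyanophenyl, gives a 1.2-fold lower number from compound 1 to compound 3 (0.07 log units; within the scatter), so among these three compounds only the 2-cyanophenyl compound stands apart. Nothing available explains this difference.

From the compounds shown here alone, it remains open whether an amine, a methoxy group or chloro on that aromatic carbon would give a number closer to compound 2 or to compound 3.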